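A few compounds are considered here, and "the series" means these few. Any claim that something is new, unique, unknown or untested is made for them only; others in the source may bear on it.

Of the compounds shown here, three built on a shared core have been tested in a functional assay on THP-1 cells (Homo sapiens) for cytotoxicity, read by sulforhodamine B assay, with a stated time of 48 h; on this read-out lower numbers stand for stronger inhibition and higher numbers for weaker inhibition. Compound 1 `COc1cc(/C=C/C(=O)/C=C/c2cc(OC)c(OC)c(OC)c2)ccc1OCc1cn(CCCOc2cc(=O)oc3ccccc23)nn1` gives 5430 nM, compound 2 `COc1cc(/C=C/C(=O)/C=C/c2cccc3ccccc23)ccc1OCc1cn(CCCOc2cc(=O)oc3ccccc23)nn1` gives 8410 nM, and compound 3 `COc1ccc(/C=C/C(=O)/C=C/c2ccc(OCc3cn(CCOc4cc(=O)oc5ccccc45)nn3)c(OC)c2)cc1` gives 7410 nM. Compound 2 holds the highest of the three numbers, yet its nearest neighbour, compound 3, lies within the scatter, and so does compound 1, so none of the three can be set apart from the others. Compound 4 `COc1ccc(/C=C/C(=O)/C=C/c2ccc(OCc3cn(CCCOc4cc(=O)oc5ccccc45)nn3)c(OC)c2)cc1OC` has not yet been measured. Its difference from compound 2 is 3,4-dimethoxyphenyl in place of naphthalen-1-yl on a double-bonded chain carbon bound to a double-bonded chain carbon. Going by the values given here, one measured step bears on this change, running the other way: a 1.5-fold higher number from compound 1 to compound 2 (0.19 log units; within the scatter). Exchanging naphthalen-1-yl and 3,4,5-trimethoxyphenyl at this place thus left the number within the scatter. For compound 4 a step of a 1.4-fold lower number from compound 2 to compound 4 (0.15 log units; within the scatter) is therefore expected, with no move beyond the scatter in either direction. Compound 4 is estimated at 6000 nM, in a range from 3500 nM to 10500 nM.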

Compound 4, half-maximal inhibitory concentration: 8510 nM
Compound 4: middle estimate off by 1.4-fold (0.15 log units), on the low side; measured number inside the range.
By their numbers in this assay, from the lowest: compounds 1, 3, 2 and 4 (each within the scatter of the next).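

In this assay, the exchange at this place now covers a larger structural difference: two six-membered aromatic rings with no hydrogen-bond acceptors give way to one such ring with two acceptors, and the result is a 1.0-fold higher number from compound 2 to compound 4 (0.01 log units; within the scatter), within the scatter. Taking one methoxy off the 3,4,5-trimethoxyphenyl group, with hydrogen in its place, gives a 1.6-fold higher number from compound 1 to compound 4 (0.20 log units; within the scatter), also within the scatter, so all three aromatic groups tried at this place remain indistinguishable. No measured evidence is available to explain this result.

All three groups at this place are built on aromatic rings of carbon only. As far as these compounds go, it remains open whether an amine or a carboxylic acid on this chain carbon would move the number beyond the scatter.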